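Methylation of the oxime in a dithiole series

A few compounds are considered here, and "the series" means these few. Any claim that something is new, unique, unknown or untested is made for them only; others in the source may bear on it.

Measured compounds in a functional assay on HT-1080 cells (Homo sapiens) for antiproliferative activity, read by MTT assay, with a stated time of 72 h; on this read-out higher numbers stand for weaker inhibition and lower numbers for stronger inhibition:
compound 1 `COc1ccc(-c2ss/c(=N/O)c2-c2cc(OC)c(OC)c(OC)c2)cc1O` gives 730 nM;
compound 2 `COc1ccc(-c2c(-c3cc(OC)c(OC)c(OC)c3)ss/c2=N/O)cc1[N+](=O)[O-]` gives 3030 nM;
compound 3 `CO/N=c1/ssc(-c2ccc(OC)c(O)c2)c1-c1cc(OC)c(OC)c(OC)c1` gives 4600 nM.

Compound 1 and compound 3 share one core and differ in a single place: methyl in place of hydrogen on an oxygen. This change gave a 6.3-fold higher number from compound 1 to compound 3 (0.80 log units; beyond the scatter), so in this assay compound 3 is the weaker inhibitor of the pair, beyond the usual scatter.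

Compound 2 carries a nitro group where compound 1 has a hydroxy group; the difference between the two cores is not broken down here. Compound 2 gives a higher number than compound 1 in this assay, and its value sits within the scatter of that of compound 3.

Compound 4 `CO/N=c1/ssc(-c2cc(OC)c(OC)c(OC)c2)c1-c1ccc(OC)c([N+](=O)[O-])c1` is not yet measured. It stands to compound 2 as compound 3 stands to compound 1: methyl in place of hydrogen on an oxygen. The place of the change is the same in both pairs, an oxygen whose other neighbour is a double-bonded nitrogen, so this is the same change. For the measured compounds named here, with only one measured example of the change, the expectation rests on that single step: the step is expected to be a 5.0-fold higher number from compound 2 to compound 4 (0.69 log units; beyond the scatter), close to a 6.3-fold higher number from compound 1 to compound 3 (0.80 log units; beyond the scatter), somewhat damped because compound 2 already starts from 3030 nM. Compound 4 is therefore expected to give 15000 nM in this assay, with a likely range from 6000 nM to 40000 nM.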

Compound 4, half-maximal inhibitory concentration: > 100000 nM
Compound 4 gave a limit, no number; the forecaster's own chance of this, stated with the estimate: 10%; middle value at least 6.6-fold (0.82 log units) away from the limit.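

In this assay compound 4 gives > 100000 nM, which is a limit of the assay and not a number. Methyl in place of hydrogen on the oxime oxygen raises the number on both cores, and on the core of compound 2 the step is an at least 33-fold higher number from compound 2 to compound 4 (1.51 log units; beyond the scatter), so the direction of the change carries over from one core to the other while its size does not: the same change on two cores in this assay, a 6.3-fold higher number (0.80 log units; beyond the scatter) from compound 1 to compound 3 and an at least 33-fold higher number (1.51 log units; beyond the scatter) from compound 2 to compound 4, at least 5.2-fold (0.71 log units) apart, beyond the scatter of two such steps These two pairs do not show how large the step on the core of compound 2 really is, nor why it differs in size from the step on the core of compound 1, and they set no rule for any other core in the series.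

The compounds shown leave open whether a longer chain, such as ethyl or benzyl, on the oxime oxygen would follow the same direction as methyl on either core. They also leave open how the change would behave on a core carrying an amine or a halogen such as fluorine where compound 2 has its nitro group, which would show whether the larger step is particular to that core.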